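One Ring Rearranged, With Only a Limit to Go On

The source may report more compounds than this note shows. Statements on the series, on what has been measured and on what is new or still open speak of the compounds shown alone.

Compound 1 `COC1C=C(CCC/C(C)=C/C=C/[C@@H](C)CC/C=C(/C)C[C@H]2OC(=O)C(C)=C2O)C(=O)O1` with a value (33 ug/mL)
Compound 2 `CC1=C(O)[C@@H](C/C(C)=C\CC[C@H](C)/C=C/C=C(\C)CCCC2=CCN(CC(=O)O)C2=O)OC1=O` with a limit (> 30 ug/mL)

Both compounds were tested in a functional assay on HCT-15 cells (Homo sapiens) for cytotoxicity (a higher number here means that more compound is needed for the effect, a lower number that less compound is needed), and only compound 1 gave a real number. Compound 2 stands at a limit of the assay (> 30 ug/mL) and not at a number.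

Compound 3 `CC1=C(O)[C@@H](C/C(C)=C\CC[C@H](C)/C=C/C=C(\C)CCCC2=CC(=O)N(CC(=O)O)C2)OC1=O` has the same atoms as compound 2, joined differently (a group of 10 heavy atoms (6 carbon, 1 nitrogen, 3 oxygen; one five-membered non-aromatic ring with 1 hetero atom) in place of a group of 10 heavy atoms (6 carbon, 1 nitrogen, 3 oxygen; one five-membered non-aromatic ring with 1 hetero atom), on a saturated chain carbon, three bonds along the chain from a double-bonded chain carbon). The swapped group sits on a saturated chain carbon, three bonds along the chain from a double-bonded chain carbon.

Among the compounds with values here, the one measured step at that place is a step that the limit leaves unreadable from compound 1 to compound 2 and it offers no size to carry over. It also replaces a different group, so it is only a loose guide to this change.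

In this assay no step beyond the scatter is expected, in either direction, because the limit of > 30 ug/mL in this assay, at which 1 of the 2 values shown sits, leaves no measured size to build on. The expected step is a step that the limit leaves unreadable from compound 2 to compound 3 and it remains an estimate. Compound 3 is estimated at 35 ug/mL with an expected range from 15 ug/mL to 80 ug/mL and it may well return only a limit.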

Compound 3, concentration for half-maximal effect: > 30 ug/mL
Compound 3 ended at the assay's limit (the forecaster's own chance of this, stated with the estimate: 65%); the middle value lies beyond the limit too.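

Compound 3 gives > 30 ug/mL, which is a limit of the assay and not a number. With compound 2 at a limit as well, no step among compound 1, compound 2 and compound 3 can be read: the limit of > 30 ug/mL in this assay, at which 2 of the 3 values shown sit.

Still open, on these data alone, is whether the differently joined groups of compound 2 and compound 3 differ at all in this assay, or differ from the group in compound 1.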